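Aryl replacement at the chain end: cytotoxicity notes

A few compounds are considered here, and "the series" means these few. Any claim that something is new, unique, unknown or untested is made for them only; others in the source may bear on it.

Measured in a functional assay on KB cells (Homo sapiens) for cytotoxicity; a lower number here means that less compound is needed, a higher number that more compound is needed for the effect:
compound 1 `COC1=C(C)C(=O)/C(=C(O)/C=C/c2cccc(OC)c2)C(=O)C1(C)C`: 3.3 ug/mL
compound 2 `COC1=C(C)C(=O)/C(=C(O)/C=C/c2ccc(F)cc2)C(=O)C1(C)C`: 3.7 ug/mL
compound 3 `C=Cc1ccccc1/C=C/C(O)=C1/C(=O)C(C)=C(OC)C(C)(C)C1=O`: 1.9 ug/mL

Compound 1 stands second highest of the three numbers in this assay. Its nearest neighbour is compound 2, with a 1.1-fold higher number from compound 1 to compound 2 (0.05 log units; within the scatter). Its furthest is compound 3, with a 1.7-fold lower number from compound 1 to compound 3 (0.24 log units; within the scatter). The remaining pair gives a 1.9-fold lower number from compound 2 to compound 3 (0.29 log units; within the scatter). All three steps change only the aryl group on a double-bonded chain carbon bound to a double-bonded chain carbon, and none of them leaves the scatter.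

Compound 4 `COC1=C(C)C(=O)/C(=C(O)/C=C/c2cccs2)C(=O)C1(C)C` is not yet measured. Relative to compound 1 it differs as follows.

thiophen-2-yl in place of 3-methoxyphenyl on a double-bonded chain carbon bound to a double-bonded chain carbon

Among the measured compounds shown here, no measured step involves thiophen-2-yl, so the only guidance is that the three aryl exchanges made at this same place, from compound 1 to compound 2, from compound 1 to compound 3 and from compound 2 to compound 3, all stayed within the scatter. On that basis no step beyond the scatter is expected in this assay for compound 4, in either direction. The expected step from compound 1 is a 1.1-fold lower number from compound 1 to compound 4 (0.04 log units; within the scatter). Compound 4 is therefore estimated at 3 ug/mL in this assay, with a range from 1.2 ug/mL to 8 ug/mL.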

Compound 4, concentration for half-maximal effect: 5.5 ug/mL
Beside the measured number, compound 4's estimate is 1.8-fold (0.26 log units) below it; the measured number falls inside the stated range.
By their numbers in this assay, from the lowest: compounds 3, 1, 2 and 4 (each within the scatter of the next, the first and the last beyond it).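

In this assay, among the compounds shown here, the thiophen-2-yl exchange on a double-bonded chain carbon bound to a double-bonded chain carbon produces the first step at this place that leaves the scatter (a 2.9-fold higher number from compound 3 to compound 4 (0.46 log units; beyond the scatter)), though only a modest one, whereas the exchanges among the three earlier compounds all stayed within it. That step appears only against 2-vinylphenyl, while the exchanges from the other two aryl groups remain within the scatter (a 1.7-fold higher number from compound 1 to compound 4 (0.22 log units; within the scatter); a 1.5-fold higher number from compound 2 to compound 4 (0.17 log units; within the scatter)), so a five-membered aromatic ring with one hetero atom cannot be told apart here from 3-methoxyphenyl or 4-fluorophenyl, and this place accepts that ring without a step beyond the scatter from either group. For the compounds shown here, no measurement is at hand that bears on why the only step beyond the scatter falls between thiophen-2-yl and 2-vinylphenyl.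

Going by these compounds, with all four compounds carrying an aromatic ring at this place, it remains open whether a phenyl ring bearing an amine or a carboxylic acid, or a saturated alkyl chain in place of the ring, would stay within the same range. On these data alone, it also remains open whether the gap between compound 3 and compound 4 would hold up in repeated measurements, given how modest it is.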